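The source may report more compounds than this note shows. Statements on the series, on what has been measured and on what is new or still open speak of the compounds shown alone.

In a functional assay (Homo sapiens) for cytotoxicity (a lower number here means a stronger inhibitor, a higher number a weaker inhibitor), compound 1 `CSCSc1nc(O)c(C)c(Cc2ccccc2)n1` gives > 100000 nM, which is a limit and not a number. Compound 2 `CCc1c(O)nc(SCSC)nc1Cc1ccccc1` gives > 100000 nM, also a limit. The evidence so far is the limit of > 100000 nM in this assay, at which 2 of the 2 values shown sit. Compound 3 `CSCSc1nc(O)c(C(C)C)c(Cc2ccccc2)n1` differs from compound 2 by methyl in place of hydrogen on a saturated chain carbon bound to an aromatic carbon and a saturated chain carbon, ethyl to isopropyl. Within the data shown here, the one measured step that bears on this, a step that the two limits leave unreadable from compound 1 to compound 2, also sets methyl in place of hydrogen, but it yields no size. The expected step, a number no higher from compound 2 to compound 3 (the limit leaves the size open), is therefore none beyond the scatter in this assay, in either direction. Compound 3 is estimated at 100000 nM, within an expected range of 50000 nM to 200000 nM.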

Compound 3, half-maximal inhibitory concentration: > 100000 nM
Compound 3 was reported as a limit; the forecaster's own chance of this, stated with the estimate: 85%; the middle value lies on the limit itself.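

Compound 3, like compound 1 and compound 2, is reported only as a limit, so no step among these three compounds can be read in this assay. The compounds shown leave open how large any effect of the methyl, ethyl or isopropyl group on the shared core might be: the limit of > 100000 nM in this assay, at which 3 of the 3 values shown sit.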